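The source may report more compounds than this note shows. Statements on the series, on what has been measured and on what is new or still open speak of the compounds shown alone.

Measured so far in a functional assay on Caco-2 cells (Homo sapiens) for antiproliferative activity, read by MTT assay, with a stated time of 48 h; on this read-out lower numbers stand for stronger inhibition and higher numbers for weaker inhibition:
- compound 1 `CCn1c(C(=O)NCC#N)ccc1C(CC)(CC)c1ccc(OCCC(O)(CC)CC)c(C)c1`: > 50000 nM, a limit of the assay
- compound 2 `CCn1c(C(=O)Nc2cccc(C(F)(F)F)c2)ccc1C(CC)(CC)c1ccc(OCCC(O)(CC)CC)c(C)c1`: > 50000 nM, a limit of the assay
- compound 3 `CCOC(=O)CN(C)C(=O)c1ccc(C(CC)(CC)c2ccc(OCCC(O)(CC)CC)c(C)c2)n1CC`: 30300 nM

Of the three, only compound 3 has an actual number, 30300 nM. The other two values are limits: the limit of > 50000 nM in this assay, at which 2 of the 3 values shown sit.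

Compound 4 `CCOC(=O)C(CC(=O)OC)NC(=O)c1ccc(C(CC)(CC)c2ccc(OCCC(O)(CC)CC)c(C)c2)n1CC` keeps the shared core and differs from compound 3 in one place, on a carbonyl carbon: a group of 12 heavy atoms (7 carbon, 1 nitrogen, 4 oxygen; no ring) in place of a group of 8 heavy atoms (5 carbon, 1 nitrogen, 2 oxygen; no ring), on a carbonyl carbon. It has not yet been measured.

Two measured steps involve the same place: an at least 1.6-fold lower number from compound 1 to compound 3 (0.21 log units; that floor lies within the scatter) and an at least 1.6-fold lower number from compound 2 to compound 3 (0.21 log units; that floor lies within the scatter). Both are only floors, and both lie within the scatter. The third, a step that the two limits leave unreadable from compound 1 to compound 2, cannot be read at all. None of these steps gives a firm size or direction for a further change on this carbonyl carbon. No step beyond the scatter is therefore expected in this assay, although a result reported only as a limit would be quite possible.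

The expected change is a 1.2-fold higher number from compound 3 to compound 4 (0.06 log units; within the scatter). For compound 4 the estimated value is 35000 nM, with an expected range from 15000 nM to 70000 nM.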

Compound 4, half-maximal inhibitory concentration: 3020 nM
The estimate for compound 4 lay 12-fold (1.06 log units) above the measured number; the measured number lies below the stated range.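

In this assay, within the data shown here, the carbonyl carbon turns out to tolerate a change that can be read: the group of 12 heavy atoms with one hydrogen-bond donor, replacing ((ethoxycarbonyl)methyl)(methyl)amino, gives a 10-fold lower number from compound 3 to compound 4 (1.00 log units; beyond the scatter) and is the first step at this place to lie beyond the scatter. On the amide-type nitrogen, the same group also stands clear of the two other amides, with an at least 16-fold lower number from compound 2 to compound 4 (1.21 log units; beyond the scatter) and an at least 16-fold lower number from compound 1 to compound 4 (1.21 log units; beyond the scatter) as steps that are printed as beyond the scatter even though each starts from a limit. Compound 1 and compound 2 also carry the amide hydrogen, yet both of their values are limits of the assay, so that hydrogen alone does not account for compound 4, and the step between these two cannot be read: the limit of > 50000 nM in this assay, at which 2 of the 4 values shown sit.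

The compounds shown do not tell whether the ethyl ester, the methyl ester or the two together carry the change. On these data alone, how a free carboxylic acid in place of either ester, an amine or a longer chain would read in this assay also stays open.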